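Compound 3 and a diamine chain in place of hydroxy

A few compounds are considered here, and "the series" means these few. Any claim that something is new, unique, unknown or untested is made for them only; others in the source may bear on it.

Measured in a functional assay on MC-38 cells (Mus musculus) for antiproliferative activity, read by CCK-8 assay, with a stated time of 48 h; a higher number here means a weaker inhibitor, a lower number a stronger inhibitor:
- compound 1 `COc1ccc(/C=C\c2cc(OC)c(OC)c(OC)c2)cc1OCc1ccc(C=O)cc1`: 900 nM
- compound 2 `COc1ccc(/C=C\c2cc(OC)c(OC)c(OC)c2)cc1OCc1ccc(CN2CCCC[C@@H]2C(=O)O)cc1`: > 10000 nM (a limit of the assay, not a number)
- compound 3 `COc1ccc(/C=C\c2cc(OC)c(OC)c(OC)c2)cc1OCc1ccc(CO)cc1`: 5700 nM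

Of the two true numbers in this assay, compound 3 has the higher, 5700 nM, and compound 1 the lower, 900 nM. Compound 2 gives only a limit, > 10000 nM.

Compound 4 `COc1ccc(/C=C\c2cc(OC)c(OC)c(OC)c2)cc1OCc1ccc(CNCCN(C)C)cc1`, not yet measured, carries (2-(dimethylamino)ethyl)amino in place of hydroxy on a saturated chain carbon bound to an aromatic carbon. The nearest evidence is the change at that same place, an at least 1.7-fold lower number from compound 2 to compound 3 (0.24 log units; that floor lies within the scatter). Two further steps start from formyl: a 6.3-fold higher number from compound 1 to compound 3 (0.80 log units; beyond the scatter) and an at least 11-fold higher number from compound 1 to compound 2 (1.04 log units; beyond the scatter). None of these compounds carries the new chain, so they set only loose bounds, and no step beyond the scatter is expected. The expected step is a 1.4-fold lower number from compound 3 to compound 4 (0.15 log units; within the scatter). For compound 4 the estimate is 4000 nM, with an expected range of 1000 nM to 10000 nM.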

Compound 4, half-maximal inhibitory concentration: 1400 nM
Beside the measured number, compound 4's estimate is 2.9-fold (0.46 log units) above it; low and high end bracket the measured number.
By their numbers in this assay, from the lowest: compounds 1 and 4 (each within the scatter of the next); then compound 3. At a limit, above all of these: compound 2.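

In this assay, (2-(dimethylamino)ethyl)amino in place of hydroxy on a saturated chain carbon bound to an aromatic carbon gives a 4.1-fold lower number from compound 3 to compound 4 (0.61 log units; beyond the scatter), and in place of 2-carboxypiperidin-1-yl it gives an at least 7.1-fold lower number from compound 2 to compound 4 (0.85 log units; beyond the scatter). Compound 2 gives only a limit of the assay, so the second step is a floor: the limit of > 10000 nM in this assay, at which 1 of the 4 values shown sits. Against formyl the chain gives a 1.6-fold higher number from compound 1 to compound 4 (0.19 log units; within the scatter), so this amine chain cannot be told apart from the formyl group in this assay, whereas hydroxymethyl could.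

Going by these compounds, whether the lower number of compound 4 needs the terminal dimethylamino group or only the amine nitrogen bound to the saturated chain carbon stays open. Also open, on these data alone, is how a primary amine, a longer chain or an open-chain carboxylic acid would read at this place.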